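The source may report more compounds than this note shows. Statements on the series, on what has been measured and on what is new or still open speak of the compounds shown alone.

Working notes on the series.

Compound 1 `CC(C)[C@H](NC(=O)COc1cccc2ccccc12)C(=O)N[C@@H](CC(=O)O)C(=O)COc1ccc(-c2ccccc2)cc1` is the reference for this comparison. In a functional assay with Homo sapiens as the target (on this read-out lower numbers stand for stronger inhibition and higher numbers for weaker inhibition), compound 1 gives 38700 nM, the highest number of the three measured; compound 2 `CC(C)[C@H](NC(=O)COc1cccc2ccccc12)C(=O)N[C@@H](CC(=O)O)C(=O)COc1ccc([N+](=O)[O-])cc1` gives 22800 nM, and the step of a 1.7-fold lower number from compound 1 to compound 2 (0.23 log units; within the scatter) stays within the scatter. Compound 3 `CC(C)[C@H](NC(=O)COc1cccc2ccccc12)C(=O)N[C@@H](CC(=O)O)C(=O)COc1cccc(F)c1` gives 12000 nM, and the step of a 3.2-fold lower number from compound 1 to compound 3 (0.51 log units; beyond the scatter) is the only one of the three that goes beyond the scatter. Between compound 2 and compound 3 the step of a 1.9-fold lower number from compound 2 to compound 3 (0.28 log units; within the scatter) again lies within the scatter.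

Compound 4 `CC(C)[C@H](NC(=O)COc1cccc2ccccc12)C(=O)N[C@@H](CC(=O)O)C(=O)COc1cc(F)cc(F)c1` differs from compound 1 as follows (3,5-difluorophenyl in place of 4-phenylphenyl on an oxygen on a saturated carbon). Going by the values given here, the step that bears on it most directly is the one from compound 1 to compound 3 a 3.2-fold lower number from compound 1 to compound 3 (0.51 log units; beyond the scatter), where a single-fluorine ring replaced the same 4-phenylphenyl at the same place and the number came down modestly. The move to a 3,5-difluorophenyl is close to that change, so a step of similar size and direction is expected, with the second fluorine not clearly adding anything on the evidence of compounds 1, 2 and 3 alone. The expected step is a 3.9-fold lower number from compound 1 to compound 4 (0.59 log units; beyond the scatter). For compound 4 in this assay the estimate is 10000 nM, with a range from 4000 nM to 25000 nM.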

Compound 4, half-maximal inhibitory concentration: 15900 nM
Beside the measured number, compound 4's estimate is 1.6-fold (0.20 log units) below it, within the range that was stated.
By their numbers in this assay, from the lowest: compounds 3, 4, 2 and 1 (each within the scatter of the next, the first and the last beyond it).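

In this assay, the 3,5-difluorophenyl on this oxygen gives a 2.4-fold lower number from compound 1 to compound 4 (0.39 log units; beyond the scatter), so compound 4 joins compound 3 as a second case of a fluorinated single ring lying beyond the scatter from the 4-phenylphenyl of compound 1, while compound 2, with its 4-nitrophenyl, stays within the scatter of compound 1 and does not share this pattern. The added fluorine itself gives no readable change, with a 1.3-fold higher number from compound 3 to compound 4 (0.12 log units; within the scatter), and exchanging the 4-nitrophenyl for the 3,5-difluorophenyl gives a 1.4-fold lower number from compound 2 to compound 4 (0.16 log units; within the scatter), so compounds 2, 3 and 4 cannot be separated from one another at this position. No measurement in hand accounts for any of these steps.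

Going by these compounds, it remains open whether the separation from compound 1 follows the loss of the second aromatic ring or the presence of fluorine, a question that a plain phenyl on the same oxygen would help to settle. Also open, on these data alone, is how this position responds to a ring carrying an amine or a carboxylic acid, or to a simple alkyl chain in place of the ring.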